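Swapping the aryl group on the shared core: clearance outlook

The source may hold more compounds than are shown below. What is called first, only, known or untested is meant among the compounds shown, and "the series" means these compounds.

Measured compounds:
compound 1 `Nc1ccc(S(=O)(=O)N2CCN(c3ncc(C(O)(C(F)(F)F)C(F)(F)F)cc3C#CCCO)CC2)cn1` — in an ADME assay (liver) for metabolic stability, with Liver microsome (Homo sapiens) as the target, using microsomes and NADPH, with a stated time of 30 min, tested at 1 uM (a lower number here means slower removal, a higher number faster removal of the compound), compound 1 gives < 14 mL.min-1.g-1, a limit of the assay and not a number.
compound 2 `CS(=O)(=O)c1ccc(-c2cc(C(O)(C(F)(F)F)C(F)(F)F)cnc2N2CCN(S(=O)(=O)c3ccc(N)nc3)CC2)cc1` — in this assay compound 2 gives 32 mL.min-1.g-1.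

For the measured compounds named here, compound 2 holds the only number measured so far; the other value is a limit. Going by the values given here, the one measured step, an at least 2.2-fold higher number from compound 1 to compound 2 (0.35 log units; beyond the scatter), brought in 4-(methylsulfonyl)phenyl in place of 4-hydroxybut-1-yn-1-yl on an aromatic carbon, and the limit of < 14 mL.min-1.g-1 in this assay, at which 1 of the 2 values shown sits, sets its size only as a lower bound.

Compound 3 `Nc1ccc(S(=O)(=O)N2CCN(c3ncc(C(O)(C(F)(F)F)C(F)(F)F)cc3-c3ccc4ocnc4c3)CC2)cn1` differs from compound 2 by 1,3-benzoxazol-5-yl in place of 4-(methylsulfonyl)phenyl on an aromatic carbon. Among the compounds with values here, no measured step exchanges one aromatic group for another, so the step from compound 1 to compound 2 bears on this change only indirectly. Compound 3 is therefore expected to sit near compound 2, with a 1.1-fold higher number from compound 2 to compound 3 (0.04 log units; within the scatter) not beyond the scatter. In this assay compound 3 is estimated at 35 mL.min-1.g-1, within a range of 15 mL.min-1.g-1 to 85 mL.min-1.g-1.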

Compound 3, intrinsic clearance in microsomes: < 14 mL.min-1.g-1
Compound 3: no number, only a limit; the forecaster's own chance of this, stated with the estimate: 15%; middle value at least 2.5-fold (0.39 log units) away from the limit.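

Exchanging one aromatic group for another at this position is not neutral in this assay: 1,3-benzoxazol-5-yl in place of 4-(methylsulfonyl)phenyl gives an at least 2.2-fold lower number from compound 2 to compound 3 (0.35 log units; beyond the scatter). An aromatic group here therefore does not by itself bring the higher number, since of the two shown only 4-(methylsulfonyl)phenyl, in compound 2, does so. Compound 3 stands at a limit of the assay, and the size of this step is known only as a lower bound: the limit of < 14 mL.min-1.g-1 in this assay, at which 2 of the 3 values shown sit.

The step between compound 1 and compound 3 cannot be read, with both compounds at limits. As far as these compounds go, it stays open whether the higher number follows the methylsulfonyl group of compound 2 or the phenyl ring that carries it, and how a plain phenyl, or a phenyl bearing an amine or a carboxylic acid, would behave at this position.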